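The source may report more compounds than this note shows. Statements on the series, on what has been measured and on what is new or still open speak of the compounds shown alone.

The compounds share one core and differ only in the group on a saturated ring carbon of the fused two-ring system. Compound 1 `O=C1Nc2c(ccc(F)c2F)C1(c1ccccc1)c1ccc(O)cc1` carries a phenyl there, and in a functional assay on MCF7 cells (Homo sapiens) for cytotoxicity, read by WST assay, with a stated time of 72 h (on this read-out higher numbers stand for weaker inhibition and lower numbers for stronger inhibition), compound 1 gives 7.1 nM, the lowest of the two numbers reported. Its nearest neighbour is compound 2 `O=C1Nc2c(ccc(F)c2F)C1(c1ccc(O)cc1)c1cccs1`, with thiophen-2-yl in place of phenyl; in this assay compound 2 gives 82 nM, so that a 12-fold higher number from compound 1 to compound 2 (1.06 log units; beyond the scatter). Compound 3 `CCCC1(c2ccc(O)cc2)C(=O)Nc2c1ccc(F)c2F` carries propyl in place of phenyl. For compound 3 this assay reports only a limit, > 1000 nM, (the limit of > 1000 nM in this assay, at which 1 of the 3 values shown sits). Accordingly an at least 140-fold higher number from compound 1 to compound 3 (2.14 log units; beyond the scatter), and an at least 12-fold higher number from compound 2 to compound 3 (1.08 log units; beyond the scatter).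

Compound 4 `O=C1Nc2c(ccc(F)c2F)C1(c1ccc(O)cc1)C1CCCC1` has not yet been measured. It differs from compound 1 in one place: cyclopentyl in place of phenyl on a saturated ring carbon. The two measured steps that bear on this change both replace the phenyl on the same saturated ring carbon, one with another aromatic ring and one with a chain, and both raise the number, the chain by far the more. A non-aromatic ring is expected to land between those two outcomes, nearer the chain, so in this assay compound 4 is expected to show a 70-fold higher number from compound 1 to compound 4 (1.85 log units; beyond the scatter). The estimated value for compound 4 is 500 nM, with a range from 100 nM to 3000 nM.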

Compound 4, half-maximal inhibitory concentration: 12 nM
The estimate for compound 4 lay 42-fold (1.62 log units) above the measured number; measured number below the stated range.
By their numbers in this assay, from the lowest: compounds 1 and 4 (each within the scatter of the next); then compound 2. At a limit, above all of these: compound 3.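

In this assay, cyclopentyl on this saturated ring carbon serves as well as phenyl, a 1.7-fold higher number from compound 1 to compound 4 (0.23 log units; within the scatter), so among the compounds shown an aromatic ring is not needed here for a low number. Within the data shown here, what the earlier compounds could not show is that the split at this position does not run between aromatic and non-aromatic groups: the step to the ring from the chain is an at least 83-fold lower number from compound 3 to compound 4 (1.92 log units; beyond the scatter), and the step from the other aromatic ring is a 6.8-fold lower number from compound 2 to compound 4 (0.83 log units; beyond the scatter), so compound 2 goes against any rule that aromatic rings do best here. The value of compound 3, > 1000 nM, is a limit and not a number, and the step from it is to be read that way: the limit of > 1000 nM in this assay, at which 1 of the 4 values shown sits.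

The compounds shown leave open whether a smaller ring such as cyclopropyl, a larger one such as cyclohexyl, or a branched chain such as isopropyl would keep the number this low, and whether a ring carrying an amine or a carboxylic acid would be tolerated. They also give no reason why cyclopentyl and propyl differ so widely at this position.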